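The source may hold more compounds than are shown below. What is called first, only, known or untested is meant among the compounds shown, and "the series" means these compounds.

For the measured compounds named here, compound 2 `O=C(/C=C/c1ccc(OCc2cn(Cc3ccc(Br)cc3)nn2)cc1)c1ccc(Br)cc1` stands at the lower of the two numbers so far: in a functional assay on A549 cells (Homo sapiens) for inhibition, read by MTT assay, with a stated time of 48 h, tested at 10 uM (on this read-out lower numbers stand for less inhibition of growth and higher numbers for more inhibition of growth at the one concentration tested), compound 2 gives 27%, while compound 1 `O=C(/C=C/c1ccc(OCc2cn(Cc3ccccc3Br)nn2)cc1)c1ccc(Br)cc1` gives 44%. Compound 3 `O=C(/C=C/c1ccc(OCc2cn(Cc3cccc(F)c3)nn2)cc1)c1ccc(Br)cc1` differs from compound 2 by 3-fluorophenyl in place of 4-bromophenyl on a saturated chain carbon bound to an aromatic nitrogen. Going by the values given here, the one measured step bears only loosely on this change: a number 17 percentage points lower from compound 1 to compound 2 (beyond the scatter) showed that exchanging one bromophenyl for another on the same carbon shifts the read-out modestly. A similar modest shift, upward this time, is expected here, as a number 6 percentage points higher from compound 2 to compound 3 (within the scatter). The estimate for compound 3 in this assay is 33%, between 15% and 52%.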

Compound 3, percent growth inhibition at one concentration: 37%
Compound 3: middle estimate off by 4 percentage points, on the low side; measured number inside the range.
By their numbers in this assay, from the lowest: compounds 2, 3 and 1 (each within the scatter of the next, the first and the last beyond it).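

On this position, 3-fluorophenyl cannot be told apart from either bromophenyl group: the read-out shows a number 10 percentage points higher from compound 2 to compound 3 (within the scatter) and a number 7 percentage points lower from compound 1 to compound 3 (within the scatter). For the compounds shown here, neither new step matches the one gap beyond the scatter, the one separating compound 1 and compound 2. Nothing available here accounts for these numbers. Compound 3 changes both the halogen and its place on the phenyl group at once, so the two changes cannot be read apart. Open too, from the compounds shown here alone, is how an amine or a carboxylic acid on this phenyl group would read.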